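A few compounds are considered here, and "the series" means these few. Any claim that something is new, unique, unknown or untested is made for them only; others in the source may bear on it.

Measured in a physicochemical assay for solubility, read by HPLC; a higher number here means a more soluble compound, a lower number a less soluble compound:
- compound 1 `COc1cccc2cc(CSc3nc4cncnc4n3[C@@H]3O[C@H](COC(C)=O)[C@@H](OC(C)=O)[C@H]3OC(C)=O)c(=O)oc12`: 78.3 ug/mL
- compound 2 `COc1cccc2cc(CSc3nc4cncnc4n3[C@@H]3O[C@H](CO)[C@@H](O)[C@H]3O)c(=O)oc12`: 224 ug/mL
- compound 3 `COc1cccc2cc(CSc3nc4cncnc4n3[C@@H]3O[C@H](CO)[C@@H]4OC(C)(C)O[C@@H]43)c(=O)oc12`: 87.7 ug/mL

Compound 2 holds the highest number of the three, and compound 1 and compound 3 both stand beyond the scatter below it. Compound 4 `COc1cccc2cc(CSc3nc4cncnc4[nH]3)c(=O)oc12` differs from compound 2 by hydrogen in place of 3,4-dihydroxy-5-(hydroxymethyl)oxolan-2-yl on an aromatic nitrogen. Going by the values given here, only one measured step touches that aromatic nitrogen: a 2.6-fold lower number from compound 2 to compound 3 (0.41 log units; beyond the scatter). That step was modest, and it exchanged one group for a larger one. Among the compounds with values here, no measured compound has hydrogen at this place, so the size of the next step is uncertain. Removing the whole group is the bigger change, so a larger step towards a lower number in this assay is expected. The estimated change is a 9.0-fold lower number from compound 2 to compound 4 (0.95 log units; beyond the scatter). For compound 4 the expected value is 25 ug/mL, with an estimated range of 6 ug/mL to 90 ug/mL.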

Compound 4, solubility: 31.6 ug/mL
The estimate for compound 4 lay 1.3-fold (0.10 log units) below the measured number, and the stated range covers the measured number.
By their numbers in this assay, from the lowest: compound 4; then compounds 1 and 3 (each within the scatter of the next); then compound 2.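

In this assay, going by these compounds alone, hydrogen in place of 3,4-dihydroxy-5-(hydroxymethyl)oxolan-2-yl on the aromatic nitrogen gives a 7.1-fold lower number from compound 2 to compound 4 (0.85 log units; beyond the scatter) and stands as the first unsubstituted comparison at this place. The larger group of compound 3 gives way to hydrogen with a 2.8-fold lower number from compound 3 to compound 4 (0.44 log units; beyond the scatter) as well, so compound 4 lies beyond the scatter below both compounds. Nothing shown gives a reason for these steps. Still open, on these data alone, is where a small group on this nitrogen, such as methyl or a short chain ending in an amine, would fall relative to hydrogen and to the groups of compound 2 and compound 3.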